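Methoxy removal on the aryl ring of compound 2

The source may report more compounds than this note shows. Statements on the series, on what has been measured and on what is new or still open speak of the compounds shown alone.

Compound 2 `COc1cc(-c2cc(/C=C/C(=O)c3ccc(N)cc3)[nH]n2)cc(OC)c1OC` gives 2000 nM in a functional assay on MDA-MB-231 cells (Homo sapiens) for inhibition, read by MTT assay, with a stated time of 48 h; a higher number here means a weaker inhibitor, a lower number a stronger inhibitor. Among the compounds with values here, on the three numbers so far it stands second highest: compound 3 `COc1cc(-c2cc(/C=C/C(=O)c3ccccc3)[nH]n2)cc(OC)c1OC` gives 2300 nM and compound 1 `COc1ccc(-c2cc(/C=C/C(=O)c3ccc(N)cc3)[nH]n2)cc1` gives 1700 nM, both within the scatter of compound 2. Within the data shown here, the only single-point step measured, a 1.2-fold higher number from compound 2 to compound 3 (0.06 log units; within the scatter), concerns the amino group and stayed within the scatter. Compound 4 `COc1ccc(-c2cc(/C=C/C(=O)c3ccc(N)cc3)[nH]n2)cc1OC` differs from compound 2 by hydrogen in place of methoxy on an aromatic carbon. Among the measured compounds shown here, no measured step addresses a methoxy group; compound 1 and compound 2, which differ in more than one place, show values within the scatter of each other. For compound 4 no step beyond the scatter is therefore expected in this assay, that is a 1.1-fold lower number from compound 2 to compound 4 (0.02 log units; within the scatter). Compound 4 is estimated at 1900 nM, with a range of 950 nM to 3800 nM.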

Compound 4, half-maximal inhibitory concentration: 2200 nM
Compound 4: the middle estimate sits 1.2-fold (0.06 log units) below what was measured; measured number inside the range.
By their numbers in this assay, from the lowest: compounds 1, 2, 4 and 3 (each within the scatter of the next).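

In this assay the methoxy groups on this aryl ring now have measured steps: hydrogen in place of methoxy, ortho to a methoxy group, gives a 1.1-fold higher number from compound 2 to compound 4 (0.04 log units; within the scatter) and methoxy in place of hydrogen gives a 1.3-fold higher number from compound 1 to compound 4 (0.11 log units; within the scatter) so neither change on this ring moves the number beyond the scatter. No information on the cause of this flat response is available.

Going by these compounds, whether a different group on this aromatic carbon, such as a hydroxyl, a fluorine or an ethoxy chain, would move the number remains open. On these data alone, the aryl ring with no methoxy group at all also remains open.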